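The source may hold more compounds than are shown below. What is called first, only, known or untested is meant among the compounds shown, and "the series" means these compounds.

Measured compounds:
compound 1, `CCCCNc1nc(C(F)(F)F)ccc1CNC(=O)C(C)c1ccc(NS(C)(=O)=O)c(F)c1`: 293 nM
compound 2, `CC1CCC(Nc2nc(C(F)(F)F)ccc2CNC(=O)C(C)c2ccc(NS(C)(=O)=O)c(F)c2)CC1`: 1130 nM
compound 3, `Cc1ccc(Cl)cc1Nc1nc(C(F)(F)F)ccc1CNC(=O)C(C)c1ccc(NS(C)(=O)=O)c(F)c1`: 140 nM

In a functional assay on CHO-K1 cells for antagonist activity at transient receptor potential cation channel subfamily V member 1 (Homo sapiens), read by FLIPR (on this read-out lower numbers stand for stronger inhibition and higher numbers for weaker inhibition), compound 3 gives the lowest number of the three; the nearest is compound 1, a 2.1-fold lower number from compound 1 to compound 3 (0.32 log units; beyond the scatter), and the furthest is compound 2, an 8.1-fold lower number from compound 2 to compound 3 (0.91 log units; beyond the scatter). Compound 4 `CCCCN(C)c1nc(C(F)(F)F)ccc1CNC(=O)C(C)c1ccc(NS(C)(=O)=O)c(F)c1` differs from compound 3 by butyl(methyl)amino in place of (5-chloro-2-methylphenyl)amino on an aromatic carbon. For the measured compounds named here, the step that bears on it is the one between compound 1 and compound 3, since compound 4 carries the same butyl chain as compound 1 but with an added methyl on the nitrogen. Going by the values given here, that methyl has no measured counterpart, so the reversal of the step from compound 1 to compound 3 is the only guide, and the effect of the methyl is open. A modest rise from compound 3 is therefore expected, a 4.3-fold higher number from compound 3 to compound 4 (0.63 log units; beyond the scatter), with a wide range. Compound 4 is estimated at 600 nM, between 200 nM and 2500 nM.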

Compound 4, half-maximal inhibitory concentration: 21.3 nM
Estimate against measurement, compound 4: 28-fold (1.45 log units) above, and the stated range ends above it.
By their numbers in this assay, from the lowest: compound 4; then compound 3; then compound 1; then compound 2.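

In this assay, methyl in place of hydrogen on the nitrogen gives a 14-fold lower number from compound 1 to compound 4 (1.14 log units; beyond the scatter), the first sign that this position needs no hydrogen on that nitrogen, since all earlier compounds kept one and varied only the other group. The butyl(methyl)amino group also beats the ring-bearing amines, with a 6.6-fold lower number from compound 3 to compound 4 (0.82 log units; beyond the scatter) and a 53-fold lower number from compound 2 to compound 4 (1.72 log units; beyond the scatter). No measured evidence accounts for these gains.

Still open, as far as these compounds go, is whether a methyl on the nitrogen of compound 3 would give a similar gain. Also open, from the compounds shown here alone, is how an ethyl in place of that methyl, or a pyrrolidine or piperidine closing the nitrogen into a ring, would compare.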